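The source may hold more compounds than are shown below. What is called first, only, known or untested is meant among the compounds shown, and "the series" means these compounds.

Of the compounds shown here, two sharing one core have been measured in an assay on isolated protein for binding affinity to sphingosine 1-phosphate receptor 2 (Homo sapiens), read by surface plasmon resonance; on this read-out higher numbers stand for weaker binding and lower numbers for tighter binding. Compound 1 `CCN(CC)c1cc(NC(=O)NNc2cc(-c3ccc(F)cc3)c3cnn(C)c3n2)cc(Cl)n1` gives 3150 nM in this assay. Compound 2 `Cc1nn(C)c2nc(NNC(=O)Nc3cc(Cl)nc(Cl)c3)cc(-c3ccco3)c12` gives 6520 nM in this assay. Compound 1 thus holds the lower of the two numbers, and its gap to compound 2 lies beyond the usual scatter of such measurements, so compound 1 is the tighter binder of the pair. Among the compounds with values here, no two measured compounds differ in a single place, so no isolated step can be read from them.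

Compound 3 `COc1cc(NC(=O)NNc2cc(-c3ccc(F)cc3)c3cnn(C)c3n2)cc(Cl)n1` has not yet been measured in this assay. It differs from compound 1 in one place: methoxy in place of diethylamino on an aromatic carbon. The diethylamino group leaves and a methoxy group enters on the aromatic carbon of the six-membered aromatic ring with one nitrogen, next to the ring nitrogen and meta to the chloro group. Nothing measured here shows what this exchange does. The expected change is a 1.6-fold higher number from compound 1 to compound 3 (0.20 log units; within the scatter), a modest move toward weaker binding. Compound 3 is therefore estimated at 5000 nM in this assay. The range for compound 3 is expected to run from 2000 nM to 15000 nM.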

Compound 3, dissociation constant: 1650 nM
Beside the measured number, compound 3's estimate is 3.0-fold (0.48 log units) above it; the measured number lies below the stated range.
By their numbers in this assay, from the lowest: compounds 3 and 1 (each within the scatter of the next); then compound 2.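

The exchange at this carbon, next to the ring nitrogen and meta to the chloro group, gives a 1.9-fold lower number from compound 1 to compound 3 (0.28 log units; within the scatter), so in this assay compound 3 cannot be told apart from compound 1. The earlier compounds shown here offered no single-place step, whereas this one shows that the diethylamino group, with its five heavy atoms, can give way to the methoxy group, with two, without a shift beyond the scatter; the count of hydrogen-bond acceptors and donors and the absence of net charge stay the same across the exchange. No measurement on hand explains this outcome.

A single exchange cannot show whether binding at this position is insensitive to the group placed there in general, or whether this result holds only for these two groups on this particular core. A plain amine, a dimethylamino group, an ethoxy group, a morpholine ring or a bare hydrogen at the same carbon could each test how far that insensitivity extends, and whether the oxygen or nitrogen attached to the ring matters at all.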